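Removing a methyl from compound 3: what cytotoxicity to expect

A few compounds are considered here, and "the series" means these few. Any claim that something is new, unique, unknown or untested is made for them only; others in the source may bear on it.

Compound 1 `O=C(CSc1c[nH]c2c(Br)cccc12)NCc1ccc(Cl)c(Cl)c1` — > 100000 nM
Compound 2 `COc1ccccc1CNC(=O)CSc1c[nH]c2cccc(Br)c12` — > 100000 nM
Compound 3 `C[C@@H](NC(=O)CSc1c[nH]c2ccccc12)c1ccccc1` — > 100000 nM

In an ADME assay on HEK-293T cells (Homo sapiens) for cytotoxicity, read by CCK-8 assay, with a stated time of 24 h (a lower number here means that less compound is tolerated, a higher number that more compound is tolerated), compound 1 gives > 100000 nM, which is a limit of the assay rather than a number. Compound 2 likewise gives > 100000 nM, again a limit. Compound 3 gives > 100000 nM, also a limit. Compound 3 therefore stands exactly where every value shown sits: the limit of > 100000 nM in this assay, at which 3 of the 3 values shown sit. Going by the values given here, no step between two measured compounds with a numeric result exists, so nothing in the data shows how a single change moves this read-out.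

Compound 4 `O=C(CSc1c[nH]c2ccccc12)NCc1ccccc1` differs from compound 3 by hydrogen in place of methyl on a saturated chain carbon bound to an amide-type nitrogen and an aromatic carbon. Among the compounds with values here, the step that the limit leaves unreadable from compound 3 to compound 4 in this assay is expected to be none beyond the scatter, since the only guide is that compound 3 and its companions all rest at the limit (the limit of > 100000 nM in this assay, at which 3 of the 3 values shown sit). Compound 4 is accordingly expected near 150000 nM, within a range of 50000 nM to 500000 nM, and most probably the assay will again report only a limit for compound 4.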

Compound 4, half-maximal cytotoxic concentration: > 100000 nM
Compound 4: no number, only a limit; the forecaster's own chance of this, stated with the estimate: 85%; the middle value lies beyond the limit too.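

Compound 3 and compound 4 both rest at a limit rather than a number in this assay, so no step between them can be read: the limit of > 100000 nM in this assay, at which 4 of the 4 values shown sit.

The compounds shown leave open at what concentration any of them would become cytotoxic, and whether the methyl changes that concentration.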